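The compounds below may be only part of what the source reports. "The series", "measured", "known", "first", "only" and "open" are said of these compounds alone.

Of the compounds shown here, two have been read so far in an ADME assay on MDBK cells (Bos taurus) for cytotoxicity (on this read-out lower numbers stand for higher toxicity in this test and higher numbers for lower toxicity in this test), and neither gives a number. Compound 1 `N#Cc1cccc(Cn2ccc3nc(-c4ccccc4)nc-3c2)c1` gives > 100000 nM which is a limit of the assay. Compound 2 `c1ccc(-c2nc3ccn(Cc4ccccn4)cc-3n2)cc1` gives > 100000 nM which is likewise a limit. Compound 2 therefore has no exact place and stands only at the limit of > 100000 nM in this assay, at which 2 of the 2 values shown sit, for now. Among the measured compounds shown here, the one measured step that bears on what follows is a step that the two limits leave unreadable from compound 1 to compound 2 and its size cannot be read. The next change leads to compound 3 `c1ccc(-c2nc3ccn(Cc4ccncc4)cc-3n2)cc1` with the same atoms joined differently: pyridin-4-yl in place of pyridin-2-yl on a saturated chain carbon bound to an aromatic nitrogen that is, pyridin-4-yl in place of pyridin-2-yl on a saturated chain carbon bound to an aromatic nitrogen. Because of the limit of > 100000 nM in this assay, at which 2 of the 2 values shown sit, covering compound 1 and compound 2, no step beyond the scatter is expected in this assay in either direction. The expected a number no higher from compound 2 to compound 3 (the limit leaves the size open) is accordingly estimated to stay small. Compound 3 is expected at 100000 nM with an estimated range from 50000 nM to 200000 nM. A limit of the assay is expected for compound 3 as well.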

Compound 3, half-maximal cytotoxic concentration: > 100000 nM
Compound 3: no number, only a limit; the forecaster's own chance of this, stated with the estimate: 80%; the middle value sits exactly at the limit.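

The steps to compound 3 from compound 1 and from compound 2 cannot be read in this assay, because all three compounds stand only at a limit: the limit of > 100000 nM in this assay, at which 3 of the 3 values shown sit. The compounds shown leave open whether exchanging the group on the saturated chain carbon changes this read-out at all.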